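Amide Aryl Swap and Tolerated Concentration in Monkey Kidney Cells

The compounds below may be only part of what the source reports. "The series", "measured", "known", "first", "only" and "open" are said of these compounds alone.

Compound 1 `CC(C)n1ncc2c(C(=O)Nc3c(F)cccc3F)cc(-c3cccs3)nc21` gives > 200000 nM in an ADME assay on LLC-MK2 cells (Macaca mulatta) for cytotoxicity, read by spectrophotometry and crystal violet staining, with a stated time of 4 days (a lower number here means that less compound is tolerated, a higher number that more compound is tolerated), a limit of the assay rather than a number.
Compound 2 `CC(C)n1ncc2c(C(=O)Nc3ccc(F)c(S(N)(=O)=O)c3)cc(-c3cccs3)nc21` gives 50000 nM in this assay.
Compound 3 `CC(C)n1ccc2c(C(=O)Nc3ccc(F)cc3)cc(-c3cccs3)nc21` gives > 200000 nM in this assay, again a limit and not a number.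

Compound 1 thus stands at the tolerated end of what is shown: it sits at the limit of > 200000 nM in this assay, at which 2 of the 3 values shown sit. Only compound 2 gives a measured number, and it lies in the same broad region of well-tolerated concentrations.

The step considered is from compound 1 to compound 4 `CC(C)n1ncc2c(C(=O)Nc3ccccn3)cc(-c3cccs3)nc21`. The change is pyridin-2-yl in place of 2,6-difluorophenyl on an amide-type nitrogen. For the measured compounds named here, no step between two measured compounds is available to size such a change in this assay, so the expectation rests on the three values shown, two of which are limits. The author expects no step beyond the scatter, an estimated a number no higher from compound 1 to compound 4 (the limit leaves the size open). Compound 4 is therefore expected at 200000 nM, with a range of 70000 nM to 400000 nM, and most likely it too will be reported only as a limit.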

Compound 4, half-maximal cytotoxic concentration: > 200000 nM
Compound 4 was reported as a limit (the forecaster's own chance of this, stated with the estimate: 65%); the middle value lies on the limit itself.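

Compound 1 and compound 4 both stand only as limits in this assay, so no step from one to the other can be read: the limit of > 200000 nM in this assay, at which 3 of the 4 values shown sit.

The compounds shown leave open whether pyridin-2-yl in place of 2,6-difluorophenyl on an amide-type nitrogen changes the tolerated concentration at all.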